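The source may hold more compounds than are shown below. What is called first, only, known or untested is meant among the compounds shown, and "the series" means these compounds.

Compound 1 `CS(=O)(=O)c1ccc(Nc2nc3cc(C(=O)O)ccc3n2Cc2ccccc2C(F)(F)F)cc1` was tested in an assay on isolated protein for inhibition of kinesin heavy chain isoform 5A (Homo sapiens); on this read-out higher numbers stand for weaker inhibition and lower numbers for stronger inhibition. In this assay compound 1 gives only a limit, > 50000 nM. Compound 2 `COC(=O)c1ccc2c(c1)nc(Nc1ccc(S(N)(=O)=O)cc1)n2Cc1ccccc1C(F)(F)F` likewise gives only a limit in this assay, > 50000 nM. Compound 3 `NS(=O)(=O)c1ccc(Nc2nc3cc(C(=O)N4CCCC4)ccc3n2Cc2ccccc2C(F)(F)F)cc1` also gives only a limit in this assay, > 50000 nM. Going by the values given here, the single step between measured neighbours, a step that the two limits leave unreadable from compound 2 to compound 3, cannot be read, because of the limit of > 50000 nM in this assay, at which 3 of the 3 values shown sit. Compound 4 `COc1ccc(CNc2nc3cc(C(=O)O)ccc3n2Cc2ccccc2C(F)(F)F)cc1` is not yet measured. It differs from compound 1 by 4-methoxybenzyl in place of 4-(methylsulfonyl)phenyl on a nitrogen on an aromatic ring. Among the compounds with values here, no measured step touches this change, and every value shown is a limit, so the expectation can only start from where compound 1 sits. Compound 4 is therefore expected to remain weak in this assay, with an estimated step of an at least 1.2-fold lower number from compound 1 to compound 4 (0.09 log units; that floor lies within the scatter) and an estimated value of 40000 nM, between 5000 nM and 200000 nM.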

Compound 4, half-maximal inhibitory concentration: > 50000 nM
Compound 4 gave a limit, no number; the forecaster's own chance of this, stated with the estimate: 70%; middle value at least 1.2-fold (0.09 log units) away from the limit.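

No step can be read from compound 1 to compound 4, as both give only a limit in this assay: the limit of > 50000 nM in this assay, at which 4 of the 4 values shown sit.

The compounds shown leave open which changes to the shared core, if any, would give a measurable inhibition.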